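This account rests on a few compounds, and the source may have more. Where it says the series, first, only, none or still open, it means among the compounds named here.

Among the compounds with values here, compound 1 `CC(C)COc1ccc2oc(/C=C/[S+](C)[O-])cc(=O)c2c1` is one of two compounds measured in a functional assay on A549 cells (Homo sapiens) for cytotoxicity, with a stated time of 48 h; a lower number here means a stronger inhibitor, a higher number a weaker inhibitor. In this assay compound 1 gives 1100 nM, the lower of the two numbers on record. Compound 2 `Cc1c(/C=C/[S+](C)[O-])oc2ccccc2c1=O` sits nearest to it; in this assay compound 2 gives 1500 nM, and the gap between compound 1 and compound 2 lies within the usual scatter, so neither can be called the stronger of the pair. Within the data shown here, no pair of measured compounds differs in a single place, so no measured step is available to guide what follows.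

Compound 3 `C[S+]([O-])/C=C/c1cc(=O)c2cc(C#N)ccc2o1` has not yet been measured in this assay. It differs from compound 1 in one place: cyano in place of isobutoxy on an aromatic carbon. Among the measured compounds shown here, since no measured step of this kind exists among the two compounds, the size of the change can only be guessed. A modest move toward a higher number, close to the edge of the scatter, is expected, meaning an estimated step of a 1.8-fold higher number from compound 1 to compound 3 (0.26 log units; within the scatter). For compound 3 the estimate in this assay is 2000 nM, with a range from 600 nM to 7000 nM.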

Compound 3, half-maximal inhibitory concentration: > 10000 nM
Compound 3 gave a limit, no number; the forecaster's own chance of this, stated with the estimate: 10%; middle value at least 5.0-fold (0.69 log units) away from the limit.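

At the aromatic carbon that is meta to a fused ring and para to a fused ring, replacing isobutoxy with cyano is not a neutral exchange in this assay, with an at least 9.0-fold higher number from compound 1 to compound 3 (0.95 log units; beyond the scatter). This is the first single-place step measured among these compounds, and it shows that the group at this position can carry the read-out beyond the scatter: compound 1 with isobutoxy gives a number, whereas compound 3 with cyano does not. The full size of the step cannot be read, as compound 3 gives only a limit of the assay: the limit of > 10000 nM in this assay, at which 1 of the 3 values shown sits.

The compounds shown leave open whether the loss comes from removing isobutoxy or from introducing cyano, as only these two groups are compared at this carbon. A methoxy group or an amine at the same position would help to separate those two readings, and a longer chain than isobutoxy would show whether the number continues to hold when more atoms are placed there.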